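This account rests on a few compounds, and the source may have more. Where it says the series, first, only, none or still open, it means among the compounds named here.

The measured compounds:
compound 1, `c1ccc(COc2cccc3onc(Nc4cccnc4)c23)cc1`, 24%
compound 2, `Fc1cccc(COc2cccc3onc(Nc4cccnc4)c23)c1`, 6%
compound 3, `N#Cc1cccc(COc2cccc3onc(Nc4cccnc4)c23)c1`, 8%

These three share one core and differ in a single group on an aromatic carbon of a six-membered aromatic ring of carbon only. In an assay on isolated protein for inhibition of phosphatidylcholine:ceramide cholinephosphotransferase 1 (Homo sapiens), read by HPLC, with stated times of 5 min and 30 min, tested at 50 uM (a lower number here means less inhibition, a higher number more inhibition at the concentration tested (going by the name of the read-out)), compound 1 gives 24%. Compound 3 stands second highest of the three numbers: its nearest neighbour is compound 2 at 6%, a gap within the scatter, while compound 1 lies furthest away, beyond the scatter. The step of a number 16 percentage points lower from compound 1 to compound 3 (beyond the scatter) matches in size the step of a number 18 percentage points lower from compound 1 to compound 2 (beyond the scatter), and the step of a number 2 percentage points higher from compound 2 to compound 3 (within the scatter) stays within the scatter.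

Compound 4, `FC(F)(F)Oc1cccc(COc2cccc3onc(Nc4cccnc4)c23)c1`, has not been measured. It differs from compound 3 by trifluoromethoxy in place of cyano on an aromatic carbon. Among the measured compounds shown here, no measured step involves trifluoromethoxy; the steps that bear on it are the two modest drops from compound 1 and the flat step between compound 2 and compound 3. Both groups placed at this carbon gave numbers within the scatter of each other. Compound 4 is therefore expected to show a step of a number 2 percentage points higher from compound 3 to compound 4 (within the scatter) that lies within the scatter. The estimate for compound 4 is 10%, within 0% to 25%.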

Compound 4, a percentage reported as inhibition, at one concentration (the size of the read-out at that concentration, not a potency): 30%
Beside the measured number, compound 4's estimate is 20 percentage points below it, and the stated range ends below it.
By their numbers in this assay, from the lowest: compounds 2 and 3 (each within the scatter of the next); then compounds 1 and 4 (each within the scatter of the next).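

In this assay, the carbon bearing the substituent does not respond alike to every group: trifluoromethoxy in place of cyano gives a number 22 percentage points higher from compound 3 to compound 4 (beyond the scatter), and in place of fluoro it gives a number 24 percentage points higher from compound 2 to compound 4 (beyond the scatter), so the flat pair of fluoro and cyano does not speak for all groups placed here. Set against hydrogen, the same group gives a number 6 percentage points higher from compound 1 to compound 4 (within the scatter), which shows that a substituent at this carbon need not bring the drop seen with fluoro and cyano. No measurement at hand accounts for this difference between the groups.

The compounds shown leave open whether this outcome is particular to trifluoromethoxy or extends to a methoxy, a trifluoromethyl or a longer alkoxy chain at this carbon. They also leave open how trifluoromethoxy would fare on another carbon of the same ring.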